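The compounds below may be only part of what the source reports. "The series", "measured", "known", "first", "only" and "open" are said of these compounds alone.

Measured compounds:
compound 1 `O=C1O[C@H]([C@@H](O)Cn2cc(-c3ccc(Br)cc3)nn2)C(OCc2ccccc2)=C1OCc1ccccc1` — 9420 nM
compound 2 `CCCCCc1ccc(-c2cn(C[C@H](O)[C@H]3OC(=O)C(OCc4ccccc4)=C3OCc3ccccc3)nn2)cc1` — 13800 nM
compound 3 `CC(C)(C)c1cn(C[C@H](O)[C@H]2OC(=O)C(OCc3ccccc3)=C2OCc2ccccc2)nn1` — 28300 nM

In a functional assay on HCT-116 cells (Homo sapiens) for antiproliferative activity, read by MTT assay, with a stated time of 72 h (a higher number here means a weaker inhibitor, a lower number a stronger inhibitor), compound 3 stands highest of the three numbers: its step to compound 2 and its step to compound 1 both lie beyond the scatter, so compound 3 is the weakest inhibitor of the set as measured. The steps toward it are a 3.0-fold higher number from compound 1 to compound 3 (0.48 log units; beyond the scatter) and a 2.1-fold higher number from compound 2 to compound 3 (0.31 log units; beyond the scatter); the step between the two aryl-bearing compounds, a 1.5-fold higher number from compound 1 to compound 2 (0.17 log units; within the scatter), stays within the scatter.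

Compound 4 `O=C1O[C@H]([C@@H](O)Cn2cc(CNS(=O)(=O)c3ccc(Cl)cc3)nn2)C(OCc2ccccc2)=C1OCc1ccccc1` is the next member. The change from compound 3 is (((4-chlorophenyl)sulfonyl)amino)methyl in place of tert-butyl on an aromatic carbon. The two steps that bear on it are those from compound 1 and compound 2 to compound 3, where replacing an aryl group by tert-butyl raised the number modestly. Among the measured compounds shown here, compound 4 returns an aromatic ring to that position, so a modest lowering is expected, though no measured step covers a sulfonamide-bearing group and the size is uncertain. The estimated step is a 2.4-fold lower number from compound 3 to compound 4 (0.37 log units; beyond the scatter). Compound 4 is therefore expected at 12000 nM, within 4500 nM to 32000 nM.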

Compound 4, half-maximal inhibitory concentration: 8380 nM
Compound 4: the middle estimate sits 1.4-fold (0.16 log units) above what was measured, and the stated range covers the measured number.
By their numbers in this assay, from the lowest: compounds 4, 1 and 2 (each within the scatter of the next); then compound 3.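

In this assay, the (((4-chlorophenyl)sulfonyl)amino)methyl group on this aromatic carbon of the triazole-free-named five-membered ring gives a 3.4-fold lower number from compound 3 to compound 4 (0.53 log units; beyond the scatter), so a group carrying a hydrogen-bond donor and hydrogen-bond acceptors also stands apart from tert-butyl, as the two aryl groups do. Against those aryl groups the change stays within the scatter, with a 1.6-fold lower number from compound 2 to compound 4 (0.22 log units; within the scatter) and a 1.1-fold lower number from compound 1 to compound 4 (0.05 log units; within the scatter), so 4-bromophenyl, 4-pentylphenyl and the entering group cannot be ordered, and compound 3 alone separates from the rest. No measurement at hand accounts for these differences.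

Still open, on these data alone, is whether any group at this position moves the number beyond the scatter from the level shared by compound 1, compound 2 and compound 4. An amine, a carboxylic acid or a longer unbranched alkyl chain on this carbon would test how far that level extends.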